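The source may hold more compounds than are shown below. What is called first, only, known or untested is meant among the compounds shown, and "the series" means these compounds.

Compound 2, with the structure `O=C(c1ccccc1Cl)N1N=C(c2cc3ccccc3oc2=O)CC1c1ccccc1`, was tested in a functional assay on PC-3 cells (Homo sapiens) for cytotoxicity, read by MTT assay, with a stated time of 48 h (on this read-out higher numbers stand for weaker inhibition and lower numbers for stronger inhibition), where compound 2 gives 6370 nM. Among the compounds with values here, the only other measured compound, compound 1, with the structure `CC1=NN(C(=O)CN2CCCCC2)C(c2ccccc2O)C1`, gives 5890 nM in this assay; the two numbers lie within the usual scatter of each other, so the data do not separate them. Compound 3, with the structure `CC(C)CNCC(=O)N1N=C(c2cc3ccccc3oc2=O)CC1c1ccccc1`, has not yet been measured. It differs from compound 2 in one place: (isobutylamino)methyl in place of 2-chlorophenyl on a carbonyl carbon. Within the data shown here, no step between measured compounds is available to show what such a change does on this read-out, so the expectation rests on compound 2 alone. The step from compound 2 to compound 3 is expected to be a 1.1-fold lower number from compound 2 to compound 3 (0.03 log units; within the scatter), that is, no change beyond the scatter in either direction. Compound 3 is therefore estimated to give 6000 nM in this assay, within a range from 2500 nM to 15000 nM.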

Compound 3, half-maximal inhibitory concentration: 1920 nM
Beside the measured number, compound 3's estimate is 3.1-fold (0.49 log units) above it; measured number below the stated range.
By their numbers in this assay, from the lowest: compound 3; then compounds 1 and 2 (each within the scatter of the next).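

In this assay, replacing 2-chlorophenyl with (isobutylamino)methyl on the carbonyl carbon attached to the amide-type nitrogen in a ring gives a 3.3-fold lower number from compound 2 to compound 3 (0.52 log units; beyond the scatter), a modest step but one beyond the scatter. This shows that the number responds to what sits at this position, and that an aromatic ring is not required there for the lower number, since compound 3 carries an open chain with no ring. Nothing measured here bears on why the number falls.

This change removes a ring and chlorine and adds a nitrogen in one step, so the compounds shown cannot say which part of the swap goes with the lower number. A pentyl chain, which has no nitrogen, or a morpholin-4-ylmethyl group, which places the nitrogen in a ring, would help separate these parts.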